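The compounds below may be only part of what the source reports. "The series", "measured", "known", "first", "only" and "open" are said of these compounds alone.

Three measured compounds share one core and differ only in the aryl group carried on the amide-type nitrogen in the ring. Compound 1 `CC(C)[C@@H]1CC[C@@H](C)C[C@@]12N(C)C(=O)[C@@H]1[C@H]3C(=O)N(c4ccccc4)C(=O)[C@H]3ON12` bears a plain phenyl, and in a functional assay, read by spectrophotometry, with a stated time of 2 h (a lower number here means a stronger inhibitor, a higher number a weaker inhibitor), compound 1 gives 2310 ug/mL. Compound 2 `COc1ccc(N2C(=O)[C@H]3[C@H](ON4[C@@H]3C(=O)N(C)[C@@]43C[C@H](C)CC[C@H]3C(C)C)C2=O)cc1` carries a 4-methoxyphenyl, and in this assay compound 2 gives 990 ug/mL. Compound 3 `Cc1cccc(N2C(=O)[C@H]3[C@H](ON4[C@@H]3C(=O)N(C)[C@@]43C[C@H](C)CC[C@H]3C(C)C)C2=O)c1` carries a 3-methylphenyl, and in this assay compound 3 gives 1930 ug/mL. Among these three numbers compound 3 holds the second highest; its nearest neighbour is compound 1, and the gap from compound 1 to compound 3 is a 1.2-fold lower number from compound 1 to compound 3 (0.08 log units; within the scatter). The step of a 2.3-fold lower number from compound 1 to compound 2 (0.37 log units; beyond the scatter) was the only one that cleared the scatter, and the step of a 1.9-fold higher number from compound 2 to compound 3 (0.29 log units; within the scatter) did not.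

Compound 4 `Cc1ccc(N2C(=O)[C@H]3[C@H](ON4[C@@H]3C(=O)N(C)[C@@]43C[C@H](C)CC[C@H]3C(C)C)C2=O)c(C)c1` has not yet been measured. Its change from compound 3 is 2,4-dimethylphenyl in place of 3-methylphenyl on an amide-type nitrogen in a ring. Among the measured compounds shown here, the steps that bear on it are those adding a methyl to the aryl ring, a 1.2-fold lower number from compound 1 to compound 3 (0.08 log units; within the scatter), and the exchange of one aryl for another, a 1.9-fold higher number from compound 2 to compound 3 (0.29 log units; within the scatter), both within the scatter. A second methyl on the aryl ring is therefore expected to produce no step beyond the scatter in this assay, so that a 1.1-fold lower number from compound 3 to compound 4 (0.03 log units; within the scatter) is the estimated step. On that basis compound 4 is expected to give about 1800 ug/mL in this assay, estimated to lie between 900 ug/mL and 3600 ug/mL.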

Compound 4, half-maximal inhibitory concentration: 430 ug/mL
The estimate for compound 4 lay 4.2-fold (0.62 log units) above the measured number, and the stated range ends above it.
By their numbers in this assay, from the lowest: compound 4; then compounds 2, 3 and 1 (each within the scatter of the next, the first and the last beyond it).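

In this assay, among the compounds shown here, the aryl group on the amide-type nitrogen proves able to shift the number well beyond the scatter, which only one earlier step had done, and then narrowly: 2,4-dimethylphenyl in place of 3-methylphenyl gives the step (a 4.5-fold lower number from compound 3 to compound 4 (0.65 log units; beyond the scatter)), and in place of plain phenyl it gives the largest step in the set (a 5.4-fold lower number from compound 1 to compound 4 (0.73 log units; beyond the scatter)). The new group also clears the best earlier aryl, 4-methoxyphenyl (a 2.3-fold lower number from compound 2 to compound 4 (0.36 log units; beyond the scatter)), so compound 4 is the strongest inhibitor of the four. A single methyl had changed nothing beyond the scatter (a 1.2-fold lower number from compound 1 to compound 3 (0.08 log units; within the scatter)), so the presence of a methyl on the aryl ring does not alone go with a lower number, and the change here belongs to the 2,4-dimethylphenyl group as a whole.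

The compounds shown leave open whether one of the two methyl groups carries the step alone, and whether a chlorophenyl or an aminophenyl at this nitrogen would hold the number as low. No measurement here speaks to why the 2,4-dimethylphenyl group behaves as it does.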